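Replacing the acid-bearing ring on the amide carbonyl

The source may report more compounds than this note shows. Statements on the series, on what has been measured and on what is new or still open speak of the compounds shown alone.

Compound 1 `CO[C@]1(C(=O)N2CC[C@](c3ccc(C(F)(C(F)(F)F)C(F)(F)F)cc3)(S(=O)(=O)c3ccc(F)cc3)C2)CC[C@H](C(=O)O)CC1` was tested in an ADME assay on microsomes from liver (Homo sapiens) for metabolic stability, with a stated time of 10 min (a lower number here means that less of the compound is left, a higher number that more of the compound is left), where compound 1 gives 82%. Within the data shown here, that is the only number in hand. Compound 2 `COC(=O)[C@H]1CC[C@H](C(=O)N2CC[C@](c3ccc(C(F)(C(F)(F)F)C(F)(F)F)cc3)(S(=O)(=O)c3ccc(F)cc3)C2)CC1` was also part of the set, but in this assay compound 2 gives "not determined" (no result reported), so compound 1 stands alone, without a second measured value to compare against.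

Compound 3 `CCC1(C(=O)N2CC[C@](c3ccc(C(F)(C(F)(F)F)C(F)(F)F)cc3)(S(=O)(=O)c3ccc(F)cc3)C2)CCS(=O)(=O)CC1` differs from compound 1 in a single place: 4-ethyl-1,1-dioxothian-4-yl in place of 4-carboxy-1-methoxycyclohexyl on a carbonyl carbon. The 4-carboxy-1-methoxycyclohexyl group, with its 1 hydrogen-bond donor, leaves, and the 4-ethyl-1,1-dioxothian-4-yl group, with 0 hydrogen-bond donors, enters on the carbonyl carbon whose other neighbour is an amide-type nitrogen in a ring. Among the measured compounds shown here, no step between two measured compounds exists here, so nothing in the data fixes the size of this change in this assay. With compound 1 at 82% as the only anchor, the expected step from compound 1 to compound 3 is a number 12 percentage points lower from compound 1 to compound 3 (beyond the scatter), a modest fall that may still sit inside the usual scatter. Compound 3 is estimated to give 70% in this assay, within a range from 45% to 92%.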

Compound 3, percent of the compound remaining: 3%
Compound 3: middle estimate off by 67 percentage points, on the high side; the whole stated range lies above it.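

In this assay, placing 4-ethyl-1,1-dioxothian-4-yl instead of 4-carboxy-1-methoxycyclohexyl on the carbonyl carbon gives a number 79 percentage points lower from compound 1 to compound 3 (beyond the scatter). Among these compounds, this is the first measured step at this position, and it shows that the group on the carbonyl carbon can have a very large effect on this read-out: with the rest of the molecule unchanged, the result goes from most of the compound remaining to almost none. No measurement shown here explains the size of this step or says which feature of either group is responsible.

The step changes several things together: the carbon-only ring becomes a ring with a sulfur atom, the carboxylic acid is lost, and a methoxy group gives way to an ethyl group, so it cannot show which of these changes matters. As far as these compounds go, it also remains open whether a group such as 4-methoxy-1,1-dioxothian-4-yl, or a cyclohexyl ring carrying a primary amide in place of the carboxylic acid, would give a result closer to that of compound 1 or to that of compound 3.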